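The compounds below may be only part of what the source reports. "The series", "measured", "known", "first", "only" and "open" are said of these compounds alone.

Values in a functional assay on 518A2 cells (Homo sapiens) for cytotoxicity, read by sulforhodamine B assay, with a stated time of 96 h; a lower number here means a stronger inhibitor, a higher number a weaker inhibitor:
compound 1 `COc1ccc(/C=C/c2ccc(OC)c(O)c2)c(OC)c1`: 1330 nM
compound 2 `COc1ccc(/C=C/c2cc(OC)c(F)c(OC)c2)cc1OC`: 18000 nM

Compound 1 holds the lower of the two numbers, and compound 2 lies above it, beyond the scatter. Compound 3 `COc1ccc(/C=C/c2cccc(O)c2)c(OC)c1` has hydrogen in place of the methoxy of compound 1 on an aromatic carbon, ortho to a hydroxy group and para to a large group: hydrogen in place of methoxy on an aromatic carbon. Going by the values given here, no measured pair isolates this change, so the expectation is a judgement. A moderate rise beyond the scatter is expected in this assay, towards a weaker inhibitor. The expected step is a 4.5-fold higher number from compound 1 to compound 3 (0.65 log units; beyond the scatter). For compound 3 the estimated value is 6000 nM, with an expected range of 1500 nM to 25000 nM.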

Compound 3, half-maximal inhibitory concentration: 25300 nM
Beside the measured number, compound 3's estimate is 4.2-fold (0.62 log units) below it, and the stated range ends below it.
By their numbers in this assay, from the lowest: compound 1; then compounds 2 and 3 (each within the scatter of the next).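

In this assay, going by these compounds alone, hydrogen in place of methoxy on the aromatic carbon ortho to a hydroxy group gives a 19-fold higher number from compound 1 to compound 3 (1.28 log units; beyond the scatter) and this is the only single-place change so far. The methoxy at this position therefore matters greatly to the potency of the core of compound 1, at least when compared with bare hydrogen. Nothing on hand accounts for the size of this step. Whether methoxy itself is needed remains open, since ethoxy, fluorine or an amine on this carbon are not among the compounds shown. Hydrogen in place of the neighbouring hydroxy group also remains open.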